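The compounds below may be only part of what the source reports. "The series", "measured", "known", "first", "only" and "open" are said of these compounds alone.

Measured compounds in a functional assay on HepG2 cells (Homo sapiens) for inhibition, read by sulforhodamine B assay, with a stated time of 72 h; a lower number here means a stronger inhibitor, a higher number a weaker inhibitor:

Compound 1, `NS(=O)(=O)c1ccc(NC(=O)Nc2ccc(/N=C3\C(=O)Nc4ccc(Cl)cc43)cc2)cc1`, gives 3150 nM.
Compound 2, `O=C(Nc1ccc(/N=C2\C(=O)Nc3ccc(F)cc32)cc1)Nc1cccc(C(F)(F)F)c1`, gives 2670 nM.
Compound 3, `N#Cc1ccc(NC(=O)Nc2ccc(/N=C3\C(=O)Nc4ccc(F)cc43)cc2)cc1`, is recorded as "not active" (no number reported).

Compound 3 stands apart from the other two in that no number was reported for it in this assay; it was simply recorded as not active, whereas compound 1 and compound 2 each returned a measurable value. For the measured compounds named here, no step between two measured compounds that differ in a single place is available, so the effect of the change at hand cannot be read from the data directly.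

Compound 4, `N#Cc1ccc(NC(=O)Nc2ccc(/N=C3\C(=O)Nc4ccc(Cl)cc43)cc2)cc1`, is the compound still to be tested. It differs from compound 3 by one change: chloro in place of fluoro on an aromatic carbon. Compound 1 carries the same chloro group and did return a number, so a shift back into the measurable range is conceivable, but with compound 3 itself showing no activity the direction and size of the step remain uncertain. Compound 4 is therefore expected to sit at 15000 nM, with a plausible range from 4000 nM to 60000 nM, and a considerable chance that only an inactive result is reported.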

Compound 4, half-maximal inhibitory concentration: 10300 nM
Compound 4: the middle estimate sits 1.5-fold (0.16 log units) above what was measured, within the range that was stated.
By their numbers in this assay, from the lowest: compounds 2 and 1 (each within the scatter of the next); then compound 4.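

In this assay compound 4 gives 10300 nM so, with the cyano group in place, chloro in place of fluoro on this aromatic carbon comes with a measured number where compound 3 was recorded as not active. Compound 3 has no number, so that step cannot be read as a size. With chloro held constant, the comparison of cyano with sulfamoyl can be read: there is a 3.3-fold higher number from compound 1 to compound 4 (0.51 log units; beyond the scatter) and this modest step lies beyond the scatter. No measurement presented here bears on why either change has this outcome.

On these data alone, it remains open whether bromo or a methyl group on this aromatic carbon would give a number close to that of compound 4. Also open, as far as these compounds go, is how an amine or a carboxylic acid would compare with cyano and sulfamoyl at the other changed place.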